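The compounds below may be only part of what the source reports. "The series", "measured", "known", "first", "only" and "open" are said of these compounds alone.

Measured in a toxicity assay on L02 cells (Homo sapiens) for cytotoxicity, read by MTT assay, with a stated time of 72 h; a higher number here means a weaker inhibitor, a lower number a stronger inhibitor:
- compound 1 `O=C1c2c[n+]([O-])c3ccccc3c2C(=O)c2c1c1ccccc1n2Cc1cn([C@H]2O[C@H](CO)[C@@H](O)[C@H]2O)nn1`: 950 nM
- compound 2 `O=C1c2c[n+]([O-])c3ccccc3c2C(=O)c2c1c1ccccc1n2Cc1cn(C[C@H](O)CO)nn1`: 1130 nM

Compound 2, at 1130 nM, stands level with compound 1 within the usual scatter. Compound 3 `O=C1c2c[n+]([O-])c3ccccc3c2C(=O)c2c1c1ccccc1n2CCCCN1CCCCC1` differs from compound 2 as follows: 3-(piperidin-1-yl)propyl in place of 1-(2,3-dihydroxypropyl)-1H-1,2,3-triazol-4-yl on a saturated chain carbon bound to an aromatic nitrogen. Among the measured compounds shown here, only one measured step bears on this, and only loosely: a 1.2-fold higher number from compound 1 to compound 2 (0.08 log units; within the scatter). For the measured compounds named here, that step kept the five-membered aromatic ring, which compound 3 no longer has, so no measured step shows a direction for this swap. The expected change is a 1.3-fold lower number from compound 2 to compound 3 (0.10 log units; within the scatter), so no clear step beyond the scatter is expected. For compound 3 the estimated value is 900 nM, with an expected range from 250 nM to 3200 nM.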

Compound 3, half-maximal inhibitory concentration: 610 nM
Compound 3: the middle estimate sits 1.5-fold (0.17 log units) above what was measured, and the stated range covers the measured number.
By their numbers in this assay, from the lowest: compounds 3, 1 and 2 (each within the scatter of the next).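

In this assay the change at this place, from a triazole side chain carrying two hydroxyl groups to 3-(piperidin-1-yl)propyl, gives a 1.9-fold lower number from compound 2 to compound 3 (0.27 log units; within the scatter) and so does not separate the two compounds. This place on the shared core therefore accepts a group with no five-membered aromatic ring and no hydrogen-bond donors without a clear shift in the number. Nothing available explains this result. Still open, as far as these compounds go, is whether a morpholine ring or a shorter chain ending in an amine at this place would move the number beyond the scatter.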